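Replacing the Aminophenyl of Compound 1 with a Dichlorophenyl

The compounds below may be only part of what the source reports. "The series", "measured", "known", "first", "only" and "open" are said of these compounds alone.

Of the compounds shown here, two have been tested so far in a functional assay on HCT-116 cells (Homo sapiens) for cytotoxicity, read by sulforhodamine B assay, with a stated time of 48 h, tested at 10 uM; a higher number here means a weaker effect of the compound at the concentration tested, a lower number a stronger effect. Compound 1 `COc1cc(-c2cc(/C=C/C(=O)c3ccc(N)cc3)[nH]n2)cc(OC)c1OC` carries a 4-aminophenyl group on its carbonyl carbon, and in this assay compound 1 gives -78%. Compound 2 `COc1ccc(-c2cc(/C=C/C(=O)c3ccc(OC)c(OC)c3)[nH]n2)cc1` differs from compound 1 in more than one place, and in this assay compound 2 gives -78%. Compound 1 thus stands level with compound 2 at the digits shown; the two values lie within the scatter of each other, so neither can be called stronger.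

Compound 3 `COc1cc(-c2cc(/C=C/C(=O)c3ccc(Cl)c(Cl)c3)[nH]n2)cc(OC)c1OC` has not yet been measured. It differs from compound 1 in one place: 3,4-dichlorophenyl in place of 4-aminophenyl on a carbonyl carbon. For the measured compounds named here, no step between two measured compounds shows what this change does, so the expectation rests only on compound 1 and on the size of the change. Because compound 1 gives -78%, a strong effect at the tested concentration, the step from compound 1 to compound 3 is expected to be small, a number 8 percentage points higher from compound 1 to compound 3 (within the scatter), and may fall within the scatter. For compound 3 the expected value in this assay is -70%, with a range from -90% to -40%.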

Compound 3, a percentage reported as activity, at one concentration (the size of the read-out at that concentration, not a potency): 16%
Compound 3: middle estimate off by 86 percentage points, on the low side, and the stated range ends below it.
By their numbers in this assay, from the lowest: compounds 1 and 2 (each within the scatter of the next); then compound 3.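

In this assay, putting 3,4-dichlorophenyl in place of 4-aminophenyl on the carbonyl carbon gives a number 94 percentage points higher from compound 1 to compound 3 (beyond the scatter). The group at this position can therefore decide most of the effect seen at the tested concentration, even with the rest of the molecule unchanged, and the two groups cannot be treated as interchangeable here. No measurement available here explains this step.

The change removes an amine and adds two chlorines at once, so the compounds shown cannot tell which of these matters, or whether both do; a plain phenyl, a phenyl with a single chlorine, or a phenyl with a hydroxyl group would help separate the two. As far as these compounds go, this is also a single step on the core of compound 1, so it remains open whether the same change would have a similar effect on another core.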